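This account rests on a few compounds, and the source may have more. Where it says the series, first, only, none or still open, it means among the compounds named here.

Measured in a toxicity assay on NIH3T3 cells (Mus musculus) for cytotoxicity, read by resazurin assay; a lower number here means that less compound is needed, a higher number that more compound is needed for the effect:
- compound 1 `CN(C)c1ccc(NCc2cncn2Cc2ccc(-c3ccccc3)cc2)cc1-c1ccccc1`: > 1000 nM
- compound 2 `Cc1cccc(-c2cccc(NCc3cncn3Cc3ccccc3)c2)c1C`: > 1000 nM
- compound 3 `COC(=O)c1ccc(NCc2cncn2Cc2cccc(C)c2)cc1-c1ccccc1`: > 10000 nM

All three values are limits of the assay, not numbers.

Compound 1 stands at the limit of > 1000 nM in this assay, at which 2 of the 3 values shown sit. Compound 4 `CCC(=O)c1ccc(NCc2cncn2Cc2ccc(-c3ccccc3)cc2)cc1-c1ccccc1` keeps the core of compound 1 but carries propanoyl in place of dimethylamino on an aromatic carbon, ortho to a phenyl group (propanoyl in place of dimethylamino on an aromatic carbon). Going by the values given here, no measured pair of compounds shows what this swap does, and no exact number is available to start from. The expected change is therefore small, towards more compound being needed, and may not exceed the usual scatter: a step that the limit leaves unreadable from compound 1 to compound 4. For compound 4 the estimated value in this assay is 3000 nM, with an expected range from 1000 nM to 20000 nM.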

Compound 4, half-maximal effective concentration: > 10000 nM
Compound 4: only a limit was reported (the forecaster's own chance of this, stated with the estimate: 70%); middle value at least 3.3-fold (0.52 log units) from the limit.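

Going by these compounds alone, compound 1 and compound 4 are both reported only as limits, not numbers, so no step between them can be read. The compounds shown leave open what propanoyl in place of dimethylamino actually changes, in size or direction.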